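Cycloheptyl to cyclopentyl on the amide-type nitrogen

The compounds below may be only part of what the source reports. "The series", "measured", "known", "first", "only" and "open" are said of these compounds alone.

In a functional assay on MIA PaCa-2 cells (Homo sapiens) for cytotoxicity, read by fluorescence, with a stated time of 48 h (on this read-out higher numbers stand for an effect only at larger amounts of compound and lower numbers for an effect already at smaller amounts), compound 1 `CC(C)=CCC/C(C)=C/CC/C(C)=C/CSC[C@H](NC(=O)CCCCCN1CCN(C)CC1)C(=O)NC1CCCCCC1` gives 2700 nM. Compound 2 `CC(C)=CCC/C(C)=C/CC/C(C)=C/CSC[C@H](NC(=O)CCCCCN1CCN(C)CC1)C(=O)NC1CCCCCCC1` gives 2500 nM, so these two numbers stand together at the top of what has been measured as numbers, within the scatter of each other. Compound 3 `CC(C)=CCC/C(C)=C/CC/C(C)=C/CSc1ccccc1C(N)=O` is reported only as a limit, > 20000 nM.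

The next step leads to compound 4 `CC(C)=CCC/C(C)=C/CC/C(C)=C/CSC[C@H](NC(=O)CCCCCN1CCN(C)CC1)C(=O)NC1CCCC1`, which carries cyclopentyl in place of cycloheptyl on an amide-type nitrogen. Within the data shown here, only one measured step bears on this change: a 1.1-fold lower number from compound 1 to compound 2 (0.03 log units; within the scatter). That step swaps cycloheptyl for cyclooctyl at the same place and moves the number by no more than the scatter. It runs toward the larger ring, however, so it is an indirect guide to a change toward the five-membered ring. Resting on compound 2 and that flat step, no clear shift in either direction is expected. The expected step is a 1.1-fold higher number from compound 1 to compound 4 (0.05 log units; within the scatter). For compound 4 the estimated value is 3000 nM, with an expected range from 1500 nM to 6500 nM.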

Compound 4, half-maximal effective concentration: 10900 nM
The estimate for compound 4 lay 3.6-fold (0.56 log units) below the measured number; the measured number lies above the stated range.
By their numbers in this assay, from the lowest: compounds 2 and 1 (each within the scatter of the next); then compound 4. At a limit, above all of these: compound 3.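

The amide-type nitrogen proves sensitive to ring size, but only on the smaller side: in this assay, cyclooctyl in place of cycloheptyl had left the number unchanged within the scatter, with a 1.1-fold lower number from compound 1 to compound 2 (0.03 log units; within the scatter). Cyclopentyl in place of cycloheptyl gives a 4.0-fold higher number from compound 1 to compound 4 (0.61 log units; beyond the scatter), and cyclopentyl in place of cyclooctyl gives a 4.4-fold higher number from compound 2 to compound 4 (0.64 log units; beyond the scatter), so the five-membered ring stands apart from the two larger rings, which match each other. Nothing given here accounts for this shift.

A cyclohexyl group on the same nitrogen would show whether the number climbs gradually as the ring shrinks or changes abruptly at cyclopentyl. On these data alone, how an open-chain group such as tert-butyl, or a ring containing nitrogen such as piperidin-4-yl, would read at this place also remains open.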